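The source may report more compounds than this note shows. Statements on the series, on what has been measured and on what is new or still open speak of the compounds shown alone.

Working notes on the series, read in an ADME assay on Akata cells (Homo sapiens) for cytotoxicity, with a stated time of 7 days; a lower number here means that less compound is tolerated, a higher number that more compound is tolerated. Compound 1 `Nc1nc(NC2CC2)c2ncn(/C=C3/CC3(CO)CO)c2n1` carries cyclopropyl on a nitrogen on the aromatic ring of the shared core, and compound 2 `Nc1nc(NC2CCCCC2)c2ncn(/C=C3/CC3(CO)CO)c2n1` carries cyclohexyl in that place. Compound 1 gives > 20000 nM as a limit of the assay, not a number. Compound 2 gives > 24000 nM, which is likewise a limit, so it has no measured number in this assay and stands level with nothing that can be ranked. The next structure is compound 3 `CSc1nc(N)nc2c1ncn2/C=C1/CC1(CO)CO`, reached by methylsulfanyl in place of cyclohexylamino on an aromatic carbon. For the measured compounds named here, the only measured step bearing on this is a step that the two limits leave unreadable from compound 1 to compound 2, so it offers no size to carry over, and it changes only the group on the nitrogen, whereas here that nitrogen itself leaves. No direction can therefore be argued from the data, and no step beyond the scatter is expected. The expected step is a step that the limit leaves unreadable from compound 2 to compound 3 as an estimate only. For compound 3 the estimated value is 25000 nM, with an expected range from 8000 nM to 100000 nM and a good chance of another limit.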

Compound 3, half-maximal cytotoxic concentration: > 20000 nM
Compound 3 gave a limit, no number; the forecaster's own chance of this, stated with the estimate: 70%; the middle value is on the limit's open side.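

In this assay compound 3 gives > 20000 nM, which is a limit and not a number, so the steps from compound 2 to compound 3 and from compound 1 to compound 3 cannot be read. The compounds shown leave open whether cyclopropylamino, cyclohexylamino and methylsulfanyl differ at all in this assay.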